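This account rests on a few compounds, and the source may have more. Where it says the series, first, only, none or still open, it means among the compounds named here.

Working notes on the series. In a functional assay on cells (Homo sapiens) for inhibition (on this read-out higher numbers stand for weaker inhibition of growth and lower numbers for stronger inhibition of growth), compound 1 `C=C/C=C\[C@H](C)[C@H](OC(N)=O)[C@@H](C)[C@H](O)CC/C=C\C(C)[C@@H](O)[C@@H](C)/C=C\CC[C@@H]1O[C@@H](OC)[C@H](C)[C@@H](OCOC)[C@@H]1C` gives 3.4 nM. Compound 2 `COCOC1=C(C)C(=O)O[C@@H](CC/C=C\[C@H](C)[C@H](O)C(C)/C=C\CC[C@@H](O)[C@H](C)[C@@H](OC(N)=O)C(C)C)[C@@H]1C` reaches only a limit in this assay, > 50 nM, and not a number. Next comes compound 3 `COCOC1=C(C)C(=O)O[C@@H](CC/C=C\[C@H](C)[C@H](O)C(C)/C=C\CC[C@@H](O)[C@H](C)[C@@H](OC(N)=O)C(C)C)[C@H]1C`, which keeps the atoms and bonds of compound 2: the two compounds have the same atoms and bonds; at least one stereo element is drawn with a configuration in one of them and without one in the other: 1 of 10 stereo elements differ; a stereocentre at a saturated ring carbon is drawn S in compound 2 and R in compound 3. The stereocentre at the saturated ring carbon is drawn S in compound 2 and R in compound 3, and nothing else differs. Going by the values given here, no measured step shows what such a change does. Compound 2 is the nearest reference, and its limit of > 50 nM is the basis of the expectation. The step expected is a step that the limit leaves unreadable from compound 2 to compound 3, toward weaker inhibition or none beyond the scatter, and it starts from a limit only. For compound 3 the estimate is 80 nM, with an expected range of 30 nM to 250 nM.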

Compound 3, concentration for 50% growth inhibition: 46 nM
The estimate for compound 3 lay 1.7-fold (0.24 log units) above the measured number, and the stated range covers the measured number.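

Going by these compounds alone, at the saturated ring carbon, the change from S to R gives the only measured stereo step (an at least 1.0-fold lower number from compound 2 to compound 3 (0.03 log units; that floor lies within the scatter)), and compound 3 gives a real number in this assay where its partner gives none. On these data alone, the true size of the step stays unknown because compound 2 carries only a limit of the assay: the limit of > 50 nM in this assay, at which 1 of the 3 values shown sits. Any reading of this step as an effect of configuration also rests on how the pair is drawn: the fact that one of compounds 2 and 3 is drawn with a defined configuration and the other without, at the place where they differ.

Open, as far as these compounds go, is how large the effect of this stereocentre becomes once compound 2 has a number rather than a limit. Also open, from the compounds shown here alone, is what a hydroxyl or an ethyl group at this saturated ring carbon would do in this assay.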